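The source may hold more compounds than are shown below. What is called first, only, known or untested is meant among the compounds shown, and "the series" means these compounds.

Compound 1 `CC(O)(C(=O)Nc1ccc(S(=O)(=O)c2ccccc2O)cc1)C(F)(F)F` is one of three measured members of this set. In a functional assay (Cavia porcellus) with sulfonylurea receptors; K-ATP channels (Homo sapiens) as the target (on this read-out lower numbers stand for stronger inhibition and higher numbers for weaker inhibition), compound 1 gives 3090 nM. Compound 3 `COc1cc(C(=O)c2ccccc2)ccc1NC(=O)C(C)(O)C(F)(F)F` gives 6100 nM in this assay, which sits within the scatter of compound 1, so no order between the two is claimed. Compound 2 `CC(O)(C(=O)Nc1ccc(S(=O)(=O)c2ccccc2)c([N+](=O)[O-])c1)C(F)(F)F` reaches only the limit of this assay, > 30000 nM, which is not a number; note (the limit of > 30000 nM in this assay, at which 1 of the 3 values shown sits). Going by the values given here, no single-change pair among the measured compounds is available.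

Compound 4 `CC(O)(C(=O)Nc1ccc(S(=O)(=O)c2cncnc2)cc1)C(F)(F)F` differs from compound 1 in one place: pyrimidin-5-yl in place of 2-hydroxyphenyl on a sulfonyl sulfur. Nothing measured speaks to this change. The expected step is a 2.6-fold higher number from compound 1 to compound 4 (0.41 log units; beyond the scatter), toward a higher number. Compound 4 is estimated at 8000 nM, with a range from 2500 nM to 30000 nM in this assay.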

Compound 4, half-maximal inhibitory concentration: > 30000 nM
Compound 4 was reported as a limit; the forecaster's own chance of this, stated with the estimate: 25%; middle value at least 3.7-fold (0.57 log units) from the limit.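

Going by these compounds alone, compound 4 gives the first single-place reading: in this assay, pyrimidin-5-yl in place of 2-hydroxyphenyl on a sulfonyl sulfur gives an at least 9.7-fold higher number from compound 1 to compound 4 (0.98 log units; beyond the scatter). The group at this position therefore matters, and this change is not tolerated within the range of the assay. The value of compound 4 is a limit, so the step has a lower bound only: the limit of > 30000 nM in this assay, at which 2 of the 4 values shown sit.

These compounds cannot separate loss of the hydroxy group from entry of the ring nitrogens. As far as these compounds go, how an amine in place of that hydroxy group would read on the core of compound 1 remains open.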